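The source may hold more compounds than are shown below. What is called first, only, known or untested is meant among the compounds shown, and "the series" means these compounds.

The three measured compounds share one core and were tested in an assay on tissue (PBMC cells) for agonist activity at Toll-like receptor 8 (Homo sapiens), with a stated time of 24 h; a lower number here means that less compound is needed, a higher number that more compound is needed for the effect. Compound 1, `CCC[C@H](CO)Nc1nc(N)nc2cccnc12`, gives 19000 nM. Compound 2, `CCC[C@@H](CO)Nc1nc(N)nc2cccnc12`, gives 430 nM. Compound 3, `CCC[C@](C)(CO)Nc1nc(N)nc2cccnc12`, gives 2400 nM. Compound 3 thus stands second highest of the three numbers, separated from compound 2 by a 5.6-fold higher number from compound 2 to compound 3 (0.75 log units; beyond the scatter) and lying well under compound 1. The largest movement in the set, a 44-fold lower number from compound 1 to compound 2 (1.65 log units; beyond the scatter), rests on (the fact that compounds 1 and 2 differ only in the configuration as drawn).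

Compound 4, `CCCCC[C@](C)(CO)Nc1nc(N)nc2cccnc12`, has not yet been measured. It differs from compound 3 by ethyl in place of hydrogen on a saturated chain carbon, four bonds along the chain from a nitrogen on an aromatic ring, so the propyl chain of compound 3 becomes a pentyl chain. Neither measured step concerns such a change: a 44-fold lower number from compound 1 to compound 2 (1.65 log units; beyond the scatter) is a change of configuration alone, and a 5.6-fold higher number from compound 2 to compound 3 (0.75 log units; beyond the scatter) is a methyl in place of hydrogen on a saturated chain carbon bound to a nitrogen on an aromatic ring. Within the data shown here, no measured step therefore bears on the lengthening of the chain, and compound 4 is expected to move no further than the scatter, with no change at the digits printed from compound 3 to compound 4 (within the scatter) as the estimated step. In this assay compound 4 is estimated at 2400 nM, expected between 800 nM and 7000 nM.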

Compound 4, half-maximal effective concentration: 580 nM
Compound 4: middle estimate off by 4.1-fold (0.62 log units), on the high side, and the stated range ends above it.
By their numbers in this assay, from the lowest: compounds 2 and 4 (each within the scatter of the next); then compound 3; then compound 1.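

Until this result, the chain had stayed a propyl chain in every measured compound, so nothing had shown how this assay responds to a change at this saturated chain carbon, four bonds along the chain from a nitrogen on an aromatic ring. Ethyl in place of hydrogen there, which turns propyl into pentyl, gives a 4.1-fold lower number from compound 3 to compound 4 (0.62 log units; beyond the scatter), so this far end of the chain is a place where the number moves beyond the scatter. The step runs in the opposite direction to a 5.6-fold higher number from compound 2 to compound 3 (0.75 log units; beyond the scatter), which is a change at a different place, and nothing given here accounts for the size or direction of the step from propyl to pentyl.

The compounds shown leave open whether the number would keep falling, level off or rise again along the series through a butyl chain to a hexyl or still longer chain, and whether an amine or a carboxylic acid at the chain end would be tolerated. They also leave open whether the same lengthening would give a step of similar size without the added methyl or in the opposite configuration.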